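The compounds below may be only part of what the source reports. "The series", "measured", "known", "first", "only" and "open" are said of these compounds alone.

Of the compounds shown here, three sharing one core have been measured in an assay on HEK293 cells for displacement of a labelled ligand from Melanocortin receptor 4 (Homo sapiens); on this read-out lower numbers stand for stronger inhibition and higher numbers for weaker inhibition. Compound 1 `CC(C)C[C@H](N)c1cc(C(F)(F)F)ccc1N1CCN(C(=O)CSc2ccc(Cl)cc2Cl)CC1` gives 1500 nM, compound 2 `CC(C)C[C@H](N)c1cc(C(F)(F)F)ccc1N1CCN(C(=O)CC(C)C(=O)c2ccc(Cl)cc2)CC1` gives 1100 nM, and compound 3 `CC(C)C[C@H](N)c1cc(C(F)(F)F)ccc1N1CCN(C(=O)COc2cccc3ccccc23)CC1` gives 2600 nM. Going by the values given here, compound 3 has the highest number of the three, but only the step of a 2.4-fold higher number from compound 2 to compound 3 (0.37 log units; beyond the scatter) lies beyond the scatter, while the step of a 1.7-fold higher number from compound 1 to compound 3 (0.24 log units; within the scatter) does not; compound 3 and compound 1 therefore cannot be told apart on these numbers. The step of a 1.4-fold lower number from compound 1 to compound 2 (0.13 log units; within the scatter) is likewise within the scatter.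

Compound 4 `Cc1ccc(OCC(=O)N2CCN(c3ccc(C(F)(F)F)cc3[C@@H](N)CC(C)C)CC2)cc1` differs from compound 3 in one place: 4-methylphenyl in place of naphthalen-1-yl on an oxygen on a saturated carbon. Among the compounds with values here, none of the measured steps makes this kind of change; each of them exchanges the whole group on the saturated chain carbon bound to the carbonyl carbon rather than the aryl group on the oxygen. The three measured steps were all small, the largest being the modest step of a 2.4-fold higher number from compound 2 to compound 3 (0.37 log units; beyond the scatter), so the numbers in this assay have moved little across quite different groups at this position. On that basis compound 4 is expected to stay close to compound 3, with a step of a 1.2-fold lower number from compound 3 to compound 4 (0.07 log units; within the scatter) that is estimated to fall within the scatter. Compound 4 is therefore estimated at 2200 nM, in a range from 800 nM to 6000 nM.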

Compound 4, inhibition constant: 4400 nM
The estimate for compound 4 lay 2.0-fold (0.30 log units) below the measured number; low and high end bracket the measured number.
By their numbers in this assay, from the lowest: compounds 2, 1, 3 and 4 (each within the scatter of the next, the first and the last beyond it).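

In this assay, swapping naphthalen-1-yl on the oxygen for 4-methylphenyl takes the group from two six-membered aromatic rings to one and from 10 heavy atoms to 7, yet it gives a 1.7-fold higher number from compound 3 to compound 4 (0.23 log units; within the scatter) and so leaves compound 3 and compound 4 indistinguishable on these numbers. The 4-methylphenoxy group does stand apart from both other groups on the saturated chain carbon bound to a carbonyl carbon, with a 2.9-fold higher number from compound 1 to compound 4 (0.47 log units; beyond the scatter) and a 4.0-fold higher number from compound 2 to compound 4 (0.60 log units; beyond the scatter) both beyond the scatter, whereas the (naphthalen-1-yl)oxy group stood apart only from the 1-((4-chlorophenyl)carbonyl)ethyl group. No other measurement accompanies these numbers, so the reason for these differences remains unknown.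

Going by these compounds alone, only two aryl groups on the oxygen can be compared here, both made of carbon alone, so it remains open what a 4-chlorophenyl group, a 4-methoxyphenyl group or a phenyl ring carrying a carboxylic acid or an amine would do there. A plain phenyl group would be needed to show whether the methyl group of 4-methylphenyl contributes anything to the number.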